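The source may hold more compounds than are shown below. What is called first, only, known or untested is meant among the compounds shown, and "the series" means these compounds.

Compounds measured so far:
Compound 1 `CCOC(=O)c1c(C)nc(-c2cccc(C#N)c2)n1OC(C)C`: 6740 nM
Compound 2 `CCOC(=O)c1c(C)nc(-c2cccc(C#N)c2)n1OCc1ccncc1`: 6200 nM
Compound 3 `CCOC(=O)c1c(C)nc(-c2cccc(C#N)c2)n1OCc1ccccc1F`: 8990 nM

In a functional assay on a cell-free system (plasma, Oryctolagus cuniculus) for inhibition, with stated times of 5 min, 1 min and 6 min (a lower number here means a stronger inhibitor, a higher number a weaker inhibitor), compound 3 gives 8990 nM, which lies within the scatter of the other two values. Compound 4 `CCOC(=O)c1c(C)nc(-c2cccc(C#N)c2)n1OCc1ccc(C)cc1` has not yet been measured. It carries 4-methylphenyl in place of 2-fluorophenyl on a saturated chain carbon bound to an oxygen on an aromatic ring.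

Within the data shown here, the closest precedent is the exchange of rings at this same carbon, a 1.5-fold higher number from compound 2 to compound 3 (0.16 log units; within the scatter). The exchanges of the whole group on oxygen are similarly small: a 1.1-fold lower number from compound 1 to compound 2 (0.04 log units; within the scatter) and a 1.3-fold higher number from compound 1 to compound 3 (0.13 log units; within the scatter). All three steps stay within the scatter, so these groups have so far made no measurable difference in this assay. Among the measured compounds shown here, no measured compound carries a methyl group on this ring, which leaves the expectation uncertain.

No step beyond the scatter is therefore expected, in either direction. The estimated step is a 1.3-fold lower number from compound 3 to compound 4 (0.11 log units; within the scatter). For compound 4 the estimated value is 7000 nM, with an expected range of 3800 nM to 13000 nM.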

Compound 4, half-maximal inhibitory concentration: 6310 nM
For compound 4 the middle estimate is 1.1-fold (0.05 log units) above the measured one; low and high end bracket the measured number.
By their numbers in this assay, from the lowest: compounds 2, 4, 1 and 3 (each within the scatter of the next).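

In this assay, a methyl group on this ring makes no measurable difference: 4-methylphenyl in place of 2-fluorophenyl gives a 1.4-fold lower number from compound 3 to compound 4 (0.15 log units; within the scatter). The same holds when 4-methylphenyl replaces pyridin-4-yl, with a 1.0-fold higher number from compound 2 to compound 4 (0.01 log units; within the scatter), and when 4-methylbenzyl replaces isopropyl on the oxygen, with a 1.1-fold lower number from compound 1 to compound 4 (0.03 log units; within the scatter). These four groups on the oxygen therefore cannot be told apart in this assay, and nothing available bears on why.

As far as these compounds go, it remains open whether an amine or a carboxylic acid on this ring, or a longer chain between the oxygen and the ring, would give a step beyond the scatter. All four compounds share the rest of the core, so it is also unknown how the numbers would respond if a carboxylic acid replaced the ethyl ester.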